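The compounds below may be only part of what the source reports. "The series", "measured", "known", "first", "only" and "open" are said of these compounds alone.

Measured compounds:
- compound 1, `CCC(=O)Nc1ccc(-c2nc3cc(C(F)(F)F)ccc3n2C2CCCCC2)cc1`: 18000 nM
- compound 2, `Cn1c(-c2ccc([N+](=O)[O-])cc2)nc2cc(C(F)(F)F)ccc21`: > 100000 nM, a limit of the assay
- compound 3, `CC(=O)Nc1ccc(-c2nc3cc(C(F)(F)F)ccc3n2C2CCCCC2)cc1`: 17000 nM

In an ADME assay on MDBK cells (Bos taurus) for cytotoxicity, read by MTT assay, with a stated time of 96 h (a higher number here means that more compound is tolerated, a lower number that less compound is tolerated), compound 3 gives the lowest of the two numbers obtained, and compound 1 sits nearest, with a 1.1-fold lower number from compound 1 to compound 3 (0.02 log units; within the scatter). For compound 2 the assay reports only a limit, (the limit of > 100000 nM in this assay, at which 1 of the 3 values shown sits), and no number. The compound to be measured is compound 4, `O=[N+]([O-])c1ccc(-c2nc3cc(C(F)(F)F)ccc3n2C2CCCCC2)cc1`, which differs from compound 3 in one place: nitro in place of acetamido on an aromatic carbon. Going by the values given here, no measured step changes this group, so none bears on it directly; the only measured step, hydrogen in place of methyl on a saturated chain carbon bound to a carbonyl carbon, stayed within the scatter. Compound 2 carries a nitro group too and shows a limit, which hints that nitro is tolerated, though its core differs in another place from compound 4. A step of a 1.8-fold higher number from compound 3 to compound 4 (0.25 log units; within the scatter) is expected, towards a higher number. Compound 4 is estimated to give 30000 nM, between 10000 nM and 100000 nM.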

Compound 4, half-maximal cytotoxic concentration: 68000 nM
Estimate against measurement, compound 4: 2.3-fold (0.36 log units) below, and the stated range covers the measured number.
By their numbers in this assay, from the lowest: compounds 3 and 1 (each within the scatter of the next); then compound 4. At a limit, above all of these: compound 2.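

In this assay, going by these compounds alone, this position on the aromatic carbon para to a large group is the first place where a change goes beyond the scatter: nitro in place of acetamido gives a 4.0-fold higher number from compound 3 to compound 4 (0.60 log units; beyond the scatter), and nitro in place of propanoylamino gives a 3.8-fold higher number from compound 1 to compound 4 (0.58 log units; beyond the scatter). The two amides themselves differ only within the scatter, so exchanging either for nitro matters here, whereas the earlier change to the amide chain did not. Both steps are modest, but they agree in direction and show that more of compound 4 is tolerated than of either amide.

Going by these compounds, compound 2 gives only a limit, so the change to cyclohexyl from methyl on the aromatic nitrogen yields just a floor, an at least 1.4-fold lower number from compound 2 to compound 4 (0.16 log units; that floor lies within the scatter), and its true size stays unknown. On these data alone, how an amine, a carboxylic acid or a plain hydrogen at this position would compare with nitro and the amides remains open.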